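The source may report more compounds than this note shows. Statements on the series, on what has been measured and on what is new or still open speak of the compounds shown alone.

Measured in a functional assay on NCI-H460 cells (Homo sapiens) for inhibition, read by sulforhodamine B assay, with a stated time of 48 h; on this read-out higher numbers stand for weaker inhibition of growth and lower numbers for stronger inhibition of growth:
- compound 1 `CCOC(=O)c1nn(-c2ccc(Cl)cc2)c(-c2ccc([N+](=O)[O-])cc2)c1CNC(C)(C)C`: > 548000 nM; 52800 nM (2 entries)
- compound 2 `Cc1ccc(-c2c(CNC(C)(C)C)c(C(=O)O)nn2-c2ccc(Cl)cc2)cc1`: > 629000 nM

Compound 2 has only the limit > 629000 nM in this assay, and this is a limit of the assay, not a number. Compound 1 shows > 548000 nM; 52800 nM (2 entries).

The next compound is compound 3 `CC(C)(C)NCc1c(C(=O)O)nn(-c2ccc(Cl)cc2)c1-c1ccc([N+](=O)[O-])cc1`, which is compound 2 with nitro in place of methyl on an aromatic carbon, 4-methylphenyl to 4-nitrophenyl (nitro in place of methyl on an aromatic carbon). Going by the values given here, no step between measured compounds is available for this change, so nothing supports expecting a shift beyond the scatter in this assay. The estimated change is an at least 1.3-fold lower number from compound 2 to compound 3 (0.14 log units; that floor lies within the scatter). This expectation rests on compound 2 with its limit of > 629000 nM, so compound 3 is also expected to be reported as a limit rather than a number. As a number, the estimate for compound 3 is 450000 nM, with an expected range from 100000 nM to 600000 nM.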

Compound 3, concentration for 50% growth inhibition: 141000 nM
The estimate for compound 3 lay 3.2-fold (0.50 log units) above the measured number; the measured number falls inside the stated range.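

In this assay, going by these compounds alone, the change from 4-methylphenyl to 4-nitrophenyl, on an aromatic carbon para to a large group, gives the only readable step so far: an at least 4.4-fold lower number from compound 2 to compound 3 (0.64 log units; beyond the scatter). The number therefore responds to the group at this place when the carboxylic acid is held constant, and compound 3 gives a measured value of 141000 nM rather than a limit. The size of the step is only a floor, because compound 2 is reported with a limit of the assay and not a number: the limit of > 629000 nM in this assay, at which 1 of the 3 values shown sits.

With one pair at this place, the series cannot show whether the shift is particular to nitro or would also appear with an amine or a nitrile in the same place, nor how large the full step from methyl to nitro is. The comparison of the ethyl ester with the carboxylic acid, both carrying 4-nitrophenyl, also cannot be read as a single step, since compound 1 has one limit and one number that do not settle on a single value: the several entries of compound 1 in this assay, > 548000 nM; 52800 nM (2 entries)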